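The source may report more compounds than this note shows. Statements on the series, on what has been measured and on what is new or still open speak of the compounds shown alone.

Compound 1 `N#C[C@@H]1CCCN1C(=O)[C@@H]1C[C@@H](CC(=O)N2CCc3ccsc3C2)C(=O)N1` was tested in an in vitro assay on cells for inhibition of Dipeptidyl peptidase 9 (Homo sapiens) (on this read-out lower numbers stand for stronger inhibition and higher numbers for weaker inhibition), and gave only a limit, > 20000 nM, not a number. The same outcome was seen for compound 2 `N#C[C@@H]1CCCN1C(=O)[C@@H]1C[C@@H](CC(=O)N2CCn3c(nnc3C(F)(F)F)C2)C(=O)N1`, which in this assay also sits at a limit, > 20000 nM. Compound 1 therefore stands at the weak end of what the measurement can report, and the two values together show nothing more than the limit of > 20000 nM in this assay, at which 2 of the 2 values shown sit.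

Compound 3 `N#C[C@@H]1CCCN1C(=O)[C@@H]1C[C@@H](CC(=O)Nc2ccccc2)C(=O)N1` has not yet been measured. It differs from compound 1 by a group of 7 heavy atoms (6 carbon, 1 nitrogen; one six-membered aromatic ring of carbon only) in place of a group of 9 heavy atoms (7 carbon, 1 nitrogen, 1 sulfur; one five-membered aromatic ring with 1 hetero atom, one six-membered non-aromatic ring with 1 hetero atom), on a carbonyl carbon. No measured step of this kind exists among these compounds, so the expectation rests on the two limits alone. The expected step from compound 1 to compound 3 in this assay is a step that the limit leaves unreadable from compound 1 to compound 3, that is, no clear gain beyond the scatter. Compound 3 is expected to give about 30000 nM in this assay, within a range from 5000 nM to 200000 nM, and most likely again only a limit.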

Compound 3, half-maximal inhibitory concentration: > 100000 nM
Compound 3: a limit, no number; the forecaster's own chance of this, stated with the estimate: 70%; at least 3.3-fold (0.52 log units) between middle value and limit.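

Compound 1 and compound 3 each give only a limit, not a number, in this assay, so the step between them cannot be read. The compounds shown leave open which group on the carbonyl carbon, if any, would give a measurable inhibition.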